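This account rests on a few compounds, and the source may have more. Where it says the series, first, only, none or still open, it means among the compounds named here.

Measured compounds in a functional assay on HeLa cells (Homo sapiens) for inhibition, read by MTT assay, with a stated time of 24 h; a lower number here means a stronger inhibitor, a higher number a weaker inhibitor:
- compound 1, `CCOC(=O)C1=Cc2ccccc2OC1(OCc1cn(CC(=O)Nc2ccc(C)cc2)nn1)C(F)(F)F`: 67400 nM
- compound 2, `CCOC(=O)C1=Cc2ccccc2OC1(OCc1cc(-c2ccc([N+](=O)[O-])cc2)no1)C(F)(F)F`: > 150000 nM, which is a limit of the assay
- compound 3, `CCOC(=O)C1=Cc2ccccc2OC1(OCc1cc(-c2ccc(Cl)cc2)no1)C(F)(F)F`: 12300 nM

Compound 1 gives the highest of the two numbers; its nearest neighbour is compound 3, whose number is lower by a gap beyond the scatter. For compound 2 only the limit of > 150000 nM in this assay, at which 1 of the 3 values shown sits, is known.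

Compound 4, `CCOC(=O)C1=Cc2ccccc2OC1(OCc1cn(CC(=O)Nc2ccc(I)cc2Cl)nn1)C(F)(F)F`, differs from compound 1 by 2-chloro-4-iodophenyl in place of 4-methylphenyl on an amide-type nitrogen. Among the compounds with values here, the only measured step, an at least 12-fold lower number from compound 2 to compound 3 (1.08 log units; beyond the scatter), swaps one aromatic substituent for another on a different part of the shared core, so it bears on the present change only loosely, though it shows that a substituent swap on the pendant phenyl ring can move the number by a large amount. With so little to go on, a modest drop in the number is expected for compound 4, that is a 2.2-fold lower number from compound 1 to compound 4 (0.35 log units; beyond the scatter), with wide uncertainty. Compound 4 is estimated at 30000 nM, within 8000 nM to 120000 nM.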

Compound 4, half-maximal inhibitory concentration: 26100 nM
Compound 4: middle estimate off by 1.1-fold (0.06 log units), on the high side, within the range that was stated.
By their numbers in this assay, from the lowest: compound 3; then compound 4; then compound 1. At a limit, above all of these: compound 2.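

Within the data shown here, replacing 4-methylphenyl with 2-chloro-4-iodophenyl on the amide-type nitrogen gives a 2.6-fold lower number from compound 1 to compound 4 (0.41 log units; beyond the scatter) in this assay, the only measured step at this position, and it shows that the number responds to a change in the aromatic group held there. The change removes the methyl group and brings in chloro and iodo together, so this single step cannot be divided among the three. Nothing measured here gives a reason for the lower number.

Going by these compounds, whether chloro or iodo alone would give a similar number remains open. So does the effect of a carboxylic acid or an amine on the phenyl ring, or of a longer chain linking the amide-type nitrogen to that ring.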